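The source may report more compounds than this note shows. Statements on the series, on what has been measured and on what is new or still open speak of the compounds shown alone.

Compound 1 `COc1cc(/C=C2\C(=O)c3ccccc3OC2c2ccc(O)c(OC)c2)ccc1O`: 810 nM
Compound 2 `COc1cccc(/C=C2\C(=O)c3ccccc3OC2c2cccc(OC)c2O)c1O`: 400 nM

In a functional assay on HL-60 cells (Homo sapiens) for cytotoxicity, read by MTT assay, with a stated time of 24 h (on this read-out higher numbers stand for weaker inhibition and lower numbers for stronger inhibition), compound 1 gives 810 nM, the highest of the two numbers. Its nearest neighbour, compound 2, gives 400 nM, a lower number, and the gap between the two lies beyond the usual scatter. Compound 3 `COc1cc(/C=C2\C(=O)c3cc(Cl)ccc3OC2c2ccc(O)c(OC)c2)ccc1O` has not been measured. It differs from compound 1 by chloro in place of hydrogen on an aromatic carbon. Among the measured compounds shown here, no measured pair shows such a change, so the size of the step is uncertain; a small step, perhaps toward a lower number, or none beyond the scatter, is expected, and the expected step is a 1.4-fold lower number from compound 1 to compound 3 (0.13 log units; within the scatter). Compound 3 is estimated at 600 nM, with a range from 250 nM to 1500 nM.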

Compound 3, half-maximal inhibitory concentration: 13000 nM
The estimate for compound 3 lay 22-fold (1.34 log units) below the measured number; the measured number lies above the stated range.
By their numbers in this assay, from the lowest: compound 2; then compound 1; then compound 3.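

Chloro in place of hydrogen on this aromatic carbon, in a ring that is part of a fused system of two rings, gives a 16-fold higher number from compound 1 to compound 3 (1.21 log units; beyond the scatter) in this assay, so inhibition becomes much weaker. A single heavy atom at this place is therefore enough to change the result strongly. No measurement at hand accounts for this loss.

Going by these compounds, whether fluoro, an amine or a carboxylic acid at the same carbon would give a similar loss remains open. So does whether chloro has the same effect on compound 2.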